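From hydroxy to methoxy, starting from a limit

A few compounds are considered here, and "the series" means these few. Any claim that something is new, unique, unknown or untested is made for them only; others in the source may bear on it.

Compound 1 `O=C(Nc1ccc(C(F)(F)F)cc1)C1CCc2ccccc2N1`: 25800 nM
Compound 2 `O=C(Nc1ccc(O)cc1)C1CCc2ccccc2N1`: > 100000 nM (a limit, not a number)

Both compounds were tested in a functional assay on NCI-H23 cells (Homo sapiens) for cytotoxicity, read by sulforhodamine B assay, with a stated time of 72 h; a higher number here means a weaker inhibitor of growth, a lower number a stronger inhibitor of growth. Compound 2 gives > 100000 nM, which is a limit of the assay and not a number. Its standing on the data is therefore only a bound: the limit of > 100000 nM in this assay, at which 1 of the 2 values shown sits.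

Compound 3 `COc1ccc(NC(=O)C2CCc3ccccc3N2)cc1` keeps the shared core and changes compound 2 in one place: methyl in place of hydrogen on an oxygen on an aromatic ring. In short, the hydroxy of compound 2 becomes methoxy in compound 3.

For the measured compounds named here, only one measured step bears on this change, and it also concerns the hydroxy group: an at least 3.8-fold higher number from compound 1 to compound 2 (0.58 log units; beyond the scatter). That step lies beyond the scatter, but it does not measure methoxy directly. On this single step, a modest move toward a lower number in this assay is expected, with a real chance that compound 3 also reaches the limit. The expected step is an at least 1.6-fold lower number from compound 2 to compound 3 (0.22 log units; that floor lies within the scatter). The estimated value for compound 3 is 60000 nM, with an expected range from 20000 nM to 150000 nM.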

Compound 3, concentration for 50% growth inhibition: 55700 nM
Beside the measured number, compound 3's estimate is 1.1-fold (0.03 log units) above it; the measured number falls inside the stated range.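

Methyl in place of hydrogen on the oxygen gives, in this assay, an at least 1.7-fold lower number from compound 2 to compound 3 (0.25 log units; that floor lies within the scatter). That step can only be read as a floor, and its true size stays unknown, because compound 2 has a limit and not a number: the limit of > 100000 nM in this assay, at which 1 of the 3 values shown sits.

The change does give methoxy a real number to set against trifluoromethyl, which the hydroxy group could not provide: a 2.2-fold higher number from compound 1 to compound 3 (0.33 log units; beyond the scatter). The trifluoromethyl group therefore keeps the lower number, by a modest margin that lies beyond the scatter.

The compounds shown leave open whether a longer chain on the same oxygen, such as ethoxy, would move the number further in the same direction as methyl did. They also leave open how a chlorine, an amine or a carboxylic acid would compare with trifluoromethyl and methoxy in the place these groups occupy, so three groups on the shared core support no general rule for this position.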